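A few compounds are considered here, and "the series" means these few. Any claim that something is new, unique, unknown or untested is made for them only; others in the source may bear on it.

Working notes on the series.

Compound 1 `O=C(CCl)Nc1cccc(Cn2nc(-c3ccc(Oc4ccccc4)cc3)cc2CO)c1` is the reference point; in a functional assay on Maver1 cells (Homo sapiens) for inhibition, read by luminescence and CellTiter-Glo, with a stated time of 72 h (a lower number here means a stronger inhibitor, a higher number a weaker inhibitor), compound 1 gives 400 nM. Compound 2 `C=CC(=O)Nc1cccc(Cn2nc(-c3ccc(Oc4ccccc4)cc3)cc2CO)c1` differs from it only at the carbonyl carbon, and in this assay compound 2 gives 6700 nM. Within the data shown here, the one measured step is a 17-fold higher number from compound 1 to compound 2 (1.22 log units; beyond the scatter), so compound 2 holds the highest of the two numbers so far and sits well beyond the scatter from compound 1.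

Compound 3 `C=CC(=O)Nc1cccc(Cn2nc(-c3ccc(Oc4ccccc4)cc3)cc2C(=O)O)c1` is the next compound to be measured. It differs from compound 2 in one place: carboxy in place of hydroxymethyl on an aromatic carbon. Among the measured compounds shown here, no measured step bears on this change; the single step available, a 17-fold higher number from compound 1 to compound 2 (1.22 log units; beyond the scatter), concerns the group on the carbonyl carbon and leaves the hydroxymethyl untouched, so it gives no guidance on the carboxy exchange. For the measured compounds named here, with no comparable step in hand, the working expectation for compound 3 is a number close to that of compound 2, with wide uncertainty in either direction. For compound 3 the estimate is 8000 nM, with a range of 2500 nM to 25000 nM. The expected step from compound 2 to compound 3 is therefore a 1.2-fold higher number from compound 2 to compound 3 (0.08 log units; within the scatter), within the scatter.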

Compound 3, half-maximal inhibitory concentration: 37400 nM
Beside the measured number, compound 3's estimate is 4.7-fold (0.67 log units) below it; the whole stated range lies below it.
By their numbers in this assay, from the lowest: compound 1; then compound 2; then compound 3.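

Among these compounds, until now the hydroxymethyl was held constant across the compounds, so this is the first reading of a change on this aromatic carbon of the five-membered aromatic ring, which lies next to the ring nitrogen. In this assay, carboxy in place of hydroxymethyl gives a 5.6-fold higher number from compound 2 to compound 3 (0.75 log units; beyond the scatter), a modest step but one that shows the number responds to the group at this position, at least with the vinyl on the carbonyl carbon held fixed. The compounds shown offer no measurement that would account for this step.

Carboxy has been read only with the vinyl on the carbonyl carbon, so it remains open whether the same exchange would move the number by a similar amount with the chloromethyl of compound 1 in that place. Also open, from the compounds shown here alone, is how a methyl ester, a primary amide, an aminomethyl or a longer hydroxyalkyl chain at this position would read in this assay against the hydroxymethyl and the carboxy, which would show whether the two readings so far belong to a wider trend.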